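This account rests on a few compounds, and the source may have more. Where it says the series, first, only, none or still open, it means among the compounds named here.

Three compounds of the shared core have results in an ADME assay on microsomes from liver (Homo sapiens) for metabolic stability, read by LC-MS, using NADPH, with a stated time of 10 min, tested at 10 uM; a lower number here means that the compound disappears faster, a higher number that the compound lasts longer. Compound 1 `Nc1ncnc2c1c(Oc1cc(C(F)(F)F)ccn1)nn2[C@H]1CC[C@@H](N)CC1` gives only a limit of the assay, > 2.41 h (the limit of > 2.41 h in this assay, at which 1 of the 3 values shown sits). Compound 3 `Nc1ncnc2c1c(Oc1cc(C(F)(F)F)ccn1)nn2[C@H]1C[C@H](F)C1` gives 2.03 h, the highest of the two numbers in this assay. Compound 2 `Nc1ncnc2c1c(Oc1cc(Cl)ccn1)nn2C1CCC1` differs from compound 3 in two places; compound 2 gives 0.333 h, a lower number that lies beyond the scatter. For the measured compounds named here, the one single-point step among the measured compounds, an at least 1.1-fold lower number from compound 1 to compound 3 (0.07 log units; that floor lies within the scatter), lies within the scatter: swapping 4-aminocyclohexyl for 3-fluorocyclobutyl on the aromatic nitrogen did not move the half-life in a way that can be read.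

Compound 4 `Nc1ncnc2c1c(Oc1cc(C(F)(F)F)ccn1)nn2C1CC1` is the next entry: cyclopropyl in place of 3-fluorocyclobutyl on an aromatic nitrogen. Going by the values given here, no measured step exchanges one small carbocycle for another at this position while the rest of the molecule is held fixed, so the direction is open. The step from compound 1 to compound 3 shows that a change at this nitrogen need not shift the number; compound 2 gives the lower number, but its two changes cannot be separated. Compound 4 is therefore expected to give 1.2 h, with a range of 0.5 h to 2.4 h. The estimated step of a 1.7-fold lower number from compound 3 to compound 4 (0.23 log units; within the scatter) is a modest fall, near the edge of the scatter.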

Compound 4, half-life: > 2.41 h
Compound 4 ended at the assay's limit (the forecaster's own chance of this, stated with the estimate: 15%); middle value at least 2.0-fold (0.30 log units) away from the limit.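

In this assay, cyclopropyl in place of 3-fluorocyclobutyl on the aromatic nitrogen gives an at least 1.1-fold higher number from compound 3 to compound 4 (0.07 log units; that floor lies within the scatter) and so no readable shift, the first such result for an exchange of one small carbocycle for another at this position with the rest of the molecule held fixed. The fluorine and the two defined stereocentres of 3-fluorocyclobutyl are therefore not needed for a half-life at this level, since compound 4 carries neither. Compound 4 now shares a limit of the assay with compound 1, so the step between those two cannot be read, and the step from the fluorinated compound gives only a floor: the limit of > 2.41 h in this assay, at which 2 of the 4 values shown sit.

Going by these compounds, how far the half-life of compound 1 and compound 4 extends past that limit remains unknown, and the change of the pyridine-side substituent and the change on the aromatic nitrogen in compound 2 remain inseparable. Also open, on these data alone, is whether an open-chain group such as isopropyl or a longer alkyl chain, or a carboxylic acid, on this nitrogen would give a half-life at the same level.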